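The source may hold more compounds than are shown below. What is called first, only, known or untested is meant among the compounds shown, and "the series" means these compounds.

Of the compounds shown here, two sharing one core have been measured so far. Compound 1 `COC(=O)c1nc(C)n(-c2ccc(Cl)cc2)n1` gives 84000 nM in a functional assay on NCI-H226 cells (Homo sapiens) for inhibition, read by MTT assay, with a stated time of 72 h (a lower number here means a stronger inhibitor of growth, a higher number a weaker inhibitor of growth), and compound 2 `COC(=O)c1nc(C(C)C)n(-c2ccc(F)cc2)n1` gives 6170 nM in this assay. Compound 2 stands lowest of the two numbers, and its nearest neighbour, compound 1, lies beyond the usual scatter above it. Compound 3 `COC(=O)c1nc(C2CCCC2)n(-c2ccc(F)cc2)n1` carries cyclopentyl in place of isopropyl on an aromatic carbon. No such change has been measured here, so only a modest move toward a lower number, or none beyond the scatter, is expected. Compound 3 is estimated at 4000 nM, within 1200 nM to 14000 nM, which means the expected step of a 1.5-fold lower number from compound 2 to compound 3 (0.19 log units; within the scatter) in this assay.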

Compound 3, concentration for 50% growth inhibition: 70500 nM
Estimate against measurement, compound 3: 18-fold (1.25 log units) below; measured number outside the range, above it.
By their numbers in this assay, from the lowest: compound 2; then compounds 3 and 1 (each within the scatter of the next).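

Swapping isopropyl for cyclopentyl on this aromatic carbon, with the rest of the molecule unchanged, gives an 11-fold higher number from compound 2 to compound 3 (1.06 log units; beyond the scatter) in this assay. Among these compounds, this is the first single-place comparison here, and it shows that this position does not treat all carbon-only groups alike: the exchange alone moves the number far beyond the scatter. Nothing available here explains that step.

As far as these compounds go, whether a cyclopropyl or a tert-butyl group at this carbon would stay close to compound 2 remains open. So does the behaviour of an amine there.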